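The source may report more compounds than this note shows. Statements on the series, on what has been measured and on what is new or still open speak of the compounds shown alone.

Measured so far in a functional assay on AN3-CA cells (Homo sapiens) for antiproliferative activity, read by MTT assay, with a stated time of 72 h; a higher number here means a weaker inhibitor, a lower number a stronger inhibitor:
compound 1 `O=C(Nc1ccc(Cl)c(-c2nnc3c(Cl)cccn23)c1)c1ccc(C(F)(F)F)cc1Cl`: > 100000 nM (a limit)
compound 2 `O=C(Nc1ccc(Cl)c(-c2nnc3c(Cl)cccn23)c1)c1ccc(F)cc1Cl`: > 100000 nM (a limit)
compound 3 `O=C(Nc1ccc(Cl)c(-c2nnc3c(Cl)cccn23)c1)c1ccc(C(F)(F)F)cc1F`: 41200 nM

Compound 2 has a limit and no number, > 100000 nM. It shares that position with compound 1: the limit of > 100000 nM in this assay, at which 2 of the 3 values shown sit.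

Compound 4 `O=C(Nc1ccc(Cl)c(-c2nnc3c(Cl)cccn23)c1)c1cccc(Cl)c1` keeps the shared core and changes the group on the carbonyl carbon: 3-chlorophenyl in place of 2-chloro-4-fluorophenyl on a carbonyl carbon. Among the compounds with values here, no measured step makes this exact exchange, but two touch the same group. One is a step that the two limits leave unreadable from compound 1 to compound 2, which gives no size. Within the data shown here, the other is an at least 2.4-fold lower number from compound 1 to compound 3 (0.38 log units; beyond the scatter), the only readable step. Compound 3, at 41200 nM, shows that a change on this group can yield a measurable number. A similar modest move towards a lower number is therefore expected, though a result at the limit remains quite possible. The expected step is an at least 2.2-fold lower number from compound 2 to compound 4 (0.34 log units; beyond the scatter). Compound 4 is estimated at 45000 nM, with an expected range of 12000 nM to 100000 nM.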

Compound 4, half-maximal inhibitory concentration: 68400 nM
Beside the measured number, compound 4's estimate is 1.5-fold (0.18 log units) below it, within the range that was stated.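

In this assay, the move to 3-chlorophenyl on the carbonyl carbon gives an at least 1.4-fold lower number from compound 2 to compound 4 (0.16 log units; that floor lies within the scatter), so the readable floor of this step stays within the usual scatter. Compound 4 is nevertheless the second compound, after compound 3, to give a number rather than a limit, and its 3-chlorophenyl group holds neither fluoro nor trifluoromethyl, so a readable number at this position requires neither substituent among the compounds shown. The limit still remains a common result in this series: the limit of > 100000 nM in this assay, at which 2 of the 4 values shown sit.

Going by these compounds, it remains open how a phenyl group carrying an amine or a carboxylic acid would behave on this carbonyl carbon. The compounds shown also leave open whether any change at this position can bring the number far below the values seen so far.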